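Notes on bromo analogs with methyl and ethyl chains

The source may report more compounds than this note shows. Statements on the series, on what has been measured and on what is new or still open speak of the compounds shown alone.

For the measured compounds named here, compound 3 `CN1C(=O)C(O)(Cc2nnn[nH]2)c2cc(Br)ccc21` is one of three compounds measured in a functional assay on PC-3 cells (Homo sapiens) for antiproliferative activity, read by MTT assay, with a stated time of 48 h; a higher number here means a weaker inhibitor, a lower number a stronger inhibitor. In this assay compound 3 gives only a limit of the assay, > 100000 nM, so no number is known for it. Compound 1 `CCN1C(=O)C(O)(Cc2nnn[nH]2)c2ccccc21` likewise gives only a limit in this assay, > 100000 nM. the limit of > 100000 nM in this assay, at which 2 of the 3 values shown sit, marks how few numbers the series holds. Going by the values given here, compound 2 `CCN1C(=O)C(O)(Cc2nnn[nH]2)c2cc(Cl)ccc21` gives 79300 nM in this assay, and an at least 1.2-fold lower number from compound 1 to compound 2 (0.10 log units; that floor lies within the scatter) is the only measured step. Compound 4 `CCN1C(=O)C(O)(Cc2nnn[nH]2)c2cc(Br)ccc21` differs from compound 3 by methyl in place of hydrogen on a saturated chain carbon bound to an amide-type nitrogen in a ring. Among the compounds with values here, no measured step covers this change, so no direction follows from the data. Compound 4 is expected to give 85000 nM in this assay, between 35000 nM and 200000 nM. That expectation rests on compound 2, which shares the ethyl chain and gives 79300 nM in this assay. The estimated step is an at least 1.1-fold lower number from compound 3 to compound 4 (0.07 log units; that floor lies within the scatter), read from a limit only.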

Compound 4, half-maximal inhibitory concentration: > 100000 nM
Compound 4: no number, only a limit (the forecaster's own chance of this, stated with the estimate: 45%); middle value at least 1.1-fold (0.07 log units) from the limit.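

With the ethyl chain held fixed, bromo in place of chloro on an aromatic carbon gives an at least 1.2-fold higher number from compound 2 to compound 4 (0.10 log units; that floor lies within the scatter). The other two new steps, methyl in place of hydrogen on the chain and bromo in place of hydrogen on the aromatic carbon, cannot be read. Going from methyl to ethyl on the bromo analogs therefore yields no direction, and the series remains mostly limits: the limit of > 100000 nM in this assay, at which 3 of the 4 values shown sit.

As far as these compounds go, whether a longer chain such as propyl, in place of ethyl, would give a number rather than a limit stays open. So does the effect of an amine on the aromatic carbon that carries bromo or chloro.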